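The source may report more compounds than this note shows. Statements on the series, on what has been measured and on what is new or still open speak of the compounds shown alone.

Among the measured compounds shown here, compound 3 `Cn1nccc1-c1cc(C(F)(F)F)ccc1[C@H]1CCc2cc(S(=O)(=O)Nc3ncccn3)ccc21` gives 2.4 in a physicochemical assay for lipophilicity (a higher number here means a more lipophilic compound, a lower number a more polar compound), the lowest of the three numbers so far, under compound 1 `O=S(=O)(Nc1ncccn1)c1ccc2c(c1)CC[C@@H]2c1ccc(C(F)(F)F)cc1-c1ccc(F)nc1` at 3.2 and compound 2 `Cn1nccc1-c1cc(C(F)(F)F)ccc1[C@H]1CCOc2cc(S(=O)(=O)Nc3ncccn3)ccc21` at 3.7. Compound 4 `Cc1ccc(-c2cc(C(F)(F)F)ccc2[C@H]2CCc3cc(S(=O)(=O)Nc4ncccn4)ccc32)cn1` has 6-methylpyridin-3-yl in place of 1-methyl-1H-pyrazol-5-yl on an aromatic carbon, meta to a trifluoromethyl group: 6-methylpyridin-3-yl in place of 1-methyl-1H-pyrazol-5-yl on an aromatic carbon. For the measured compounds named here, one measured step bears on this: 1-methyl-1H-pyrazol-5-yl in place of 6-fluoropyridin-3-yl gave a number 0.80 log units lower from compound 1 to compound 3 (beyond the scatter), modest and beyond the scatter. Going by the values given here, no measurement yet compares 6-methylpyridin-3-yl with 6-fluoropyridin-3-yl. A rise of similar size in this assay is therefore expected, the estimated change being a number 0.70 log units higher from compound 3 to compound 4 (beyond the scatter). For compound 4 the estimate is 3.1, with an expected range of 2.7 to 3.5.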

Compound 4, distribution coefficient: 2.8
Compound 4: middle estimate off by 0.30 log units, on the high side; the measured number falls inside the stated range.
By their numbers in this assay, from the lowest: compound 3; then compound 4; then compound 1; then compound 2.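

At this aromatic carbon, the ring itself matters in this assay: 6-methylpyridin-3-yl in place of 1-methyl-1H-pyrazol-5-yl gives a number 0.40 log units higher from compound 3 to compound 4 (beyond the scatter). The substituent on the pyridine ring matters too, with methyl in place of fluoro giving a number 0.40 log units lower from compound 1 to compound 4 (beyond the scatter). Nothing measured here accounts for either step. From the compounds shown here alone, whether these steps carry over to the core of compound 2 remains open. Also open, going by these compounds, is how an amine or a carboxylic acid in place of that methyl would read in this assay.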